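The source may report more compounds than this note shows. Statements on the series, on what has been measured and on what is new or still open speak of the compounds shown alone.

Measured compounds:
compound 1 `N#CC1=C(N)N(c2ccc(S(N)(=O)=O)cc2)C2=C(C(=O)CCC2)C1c1c(O)ccc2ccccc12` — 15%
compound 2 `Cc1ccoc1C1C(C#N)=C(N)N(c2ccc(S(N)(=O)=O)cc2)C2=C1C(=O)CCC2` — 45%

In a functional assay on Ehrlich cells (Mus musculus) for antiproliferative activity, read by trypan blue exclusion, with a stated time of 2 h, tested at 100 ug/mL (a lower number here means a weaker effect, a higher number a stronger effect of the compound at the concentration tested), compound 1 gives 15% and compound 2 gives 45%. Among the compounds with values here, compound 2 therefore holds the higher of the two numbers, its only neighbour being compound 1, reached through a number 30 percentage points higher from compound 1 to compound 2 (beyond the scatter). That step is the sole one measured, and it exchanged 2-hydroxynaphthalen-1-yl for 3-methylfuran-2-yl on the saturated ring carbon.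

Compound 3 `N#CC1=C(N)N(c2ccc(S(N)(=O)=O)cc2)C2=C(C(=O)CCC2)C1c1cccs1` differs from compound 2 as follows: thiophen-2-yl in place of 3-methylfuran-2-yl on a saturated ring carbon. Within the data shown here, the single measured step does not involve thiophen-2-yl, so it bears on this change only loosely, showing that the group on this saturated ring carbon can shift the read-out by a modest amount. With one five-membered aromatic ring giving way to another, the step of a number 5 percentage points lower from compound 2 to compound 3 (within the scatter) is expected to stay within the scatter. Compound 3 is estimated at 40%, with a range from 20% to 60%.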

Compound 3, a percentage reported as activity, at one concentration (the size of the read-out at that concentration, not a potency): 100%
Estimate against measurement, compound 3: 60 percentage points below; measured number outside the range, above it.
By their numbers in this assay, from the lowest: compound 1; then compound 2; then compound 3.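

In this assay, within the data shown here, the saturated ring carbon proves more sensitive than the single earlier step could show: a number 55 percentage points higher from compound 2 to compound 3 (beyond the scatter) comes from exchanging one five-membered aromatic ring with one hetero atom, 3-methylfuran-2-yl, for another, thiophen-2-yl. Two groups that match in their count of rings, donors and acceptors are therefore not interchangeable at this position, and the largest step shown, a number 85 percentage points higher from compound 1 to compound 3 (beyond the scatter), also ends at thiophen-2-yl. Nothing available here explains why this exchange matters so much.

The compounds shown leave open whether the step belongs to the sulfur that enters or to the methyl that leaves, as compound 3 changes both at once. A plain furan-2-yl on this carbon would separate the two, while a 3-methylthiophen-2-yl would test the same question from the sulfur side.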